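Butylamino for butyl on the shared core

The source may report more compounds than this note shows. Statements on the series, on what has been measured and on what is new or still open speak of the compounds shown alone.

Working notes on a small series in a functional assay (spleen, spleen) for activation, with Mus musculus as the target; a lower number here means that less compound is needed, a higher number that more compound is needed for the effect. Within the data shown here, compound 1 `CCSc1nc(N)c2nc(O)n(Cc3ccccc3)c2n1` gives 0.1 uM, and compound 2 `CCCCc1nc(N)c2nc(O)n(Cc3ccccc3)c2n1` gives 0.03 uM, the lowest of the two numbers so far; the only measured step is a 3.3-fold lower number from compound 1 to compound 2 (0.52 log units; beyond the scatter). Compound 3 `CCCCNc1nc(N)c2nc(O)n(Cc3ccccc3)c2n1` differs from compound 2 by butylamino in place of butyl on an aromatic carbon. Among the measured compounds shown here, no measured step exchanges a chain for its amino-linked counterpart, so the single step from compound 1 to compound 2 bears only loosely on this change. A step near the scatter, in either direction, is expected in this assay, as a 1.7-fold higher number from compound 2 to compound 3 (0.22 log units; within the scatter). The estimate for compound 3 is 0.05 uM, with a range from 0.01 uM to 0.3 uM.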

Compound 3, minimum effective concentration: 1 uM
Beside the measured number, compound 3's estimate is 20-fold (1.30 log units) below it, outside the stated range (above it).
By their numbers in this assay, from the lowest: compound 2; then compound 1; then compound 3.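

In this assay the change on this aromatic carbon is far from neutral: with the four-carbon chain kept, butylamino in place of butyl gives a large step (a 33-fold higher number from compound 2 to compound 3 (1.52 log units; beyond the scatter)). Butylamino in place of ethylsulfanyl also moves upward (a 10-fold higher number from compound 1 to compound 3 (1.00 log units; beyond the scatter)), so compound 3 has the highest number of the three, and the amino-linked chain sits above both the sulfur-linked and the directly attached chain. Nothing available explains this shift.

From the compounds shown here alone, it remains open whether a butoxy chain would behave more like butyl or like butylamino. Also open, going by these compounds, is whether a pentyl chain would extend the gain seen with butyl.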